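The source may report more compounds than this note shows. Statements on the series, on what has been measured and on what is new or still open speak of the compounds shown alone.

The series shares a core carrying a five-membered aromatic ring with three nitrogens, and the compounds differ in the group on an aromatic nitrogen of that ring. Compound 1 `Fc1ccccc1-n1cc(COc2ccc3c(c2)CCC3)nn1` carries a 2-fluorophenyl there. For the measured compounds named here, in an ADME assay on HEK293 cells (Homo sapiens) for inhibition, read by MTT assay, with a stated time of 48 h, tested at 25 uM (a higher number here means more inhibition at the concentration tested (going by the name of the read-out), a lower number less inhibition), compound 1 gives 21%, the only number that has been reported for this group of compounds. Compound 2 `Cc1ccc([N+](=O)[O-])cc1NC(=O)Cn1cc(COc2ccc3c(c2)CCC3)nn1` belongs to the same set, but in this assay compound 2 has "not determined" (no result reported). Compound 3 `Cc1ccccc1NC(=O)Cn1cc(COc2ccc3c(c2)CCC3)nn1` likewise has "not determined" (no result reported) in this assay. Compound 1 therefore cannot be placed relative to any neighbour.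

Compound 4 `Cc1cccc(-n2cc(COc3ccc4c(c3)CCC4)nn2)c1` has not been measured in this assay. It differs from compound 1 in one place: 3-methylphenyl in place of 2-fluorophenyl on an aromatic nitrogen. Going by the values given here, no measured pair in this set shows what such a change does in this assay, so the expectation rests on compound 1 alone. The step from compound 1 to compound 4 is estimated as a number 1 percentage points higher from compound 1 to compound 4 (within the scatter), which is expected to stay within the usual scatter rather than mark a real move in either direction. Compound 4 is therefore expected to give about 22% in this assay, with a range from 8% to 40%.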

Compound 4, a percentage reported as inhibition, at one concentration (the size of the read-out at that concentration, not a potency): 23.4%
Compound 4: middle estimate off by 1.4 percentage points, on the low side, within the range that was stated.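

In this assay, for the compounds shown here, the swap of 2-fluorophenyl for 3-methylphenyl on an aromatic nitrogen gives a number 2.4 percentage points higher from compound 1 to compound 4 (within the scatter) and provides the first measured pair at this position. The two compounds therefore cannot be told apart in this read-out, even though the groups differ in their substituent and its place on the phenyl ring. Nothing given here explains why the two groups read alike.

Steps to compound 2 and compound 3 cannot be read, so the groups they carry on that nitrogen offer no comparison with compound 1. As far as these compounds go, it remains open whether a phenyl ring bearing an amine or a carboxylic acid, or a longer chain on that nitrogen, would separate from compound 1 in this assay by more than the scatter.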